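This account rests on a few compounds, and the source may have more. Where it says the series, first, only, none or still open, it means among the compounds named here.

Among the compounds with values here, in a functional assay on HeLa cells (Homo sapiens) for inhibition, read by CCK-8 assay, with a stated time of 48 h (on this read-out lower numbers stand for stronger inhibition and higher numbers for weaker inhibition), compound 1 `COc1cc(-c2ccnc3cc(-c4ccc5cc[nH]c5c4)nn23)cc(OC)c1OC` gives 125 nM, the lowest of the two numbers measured so far. Compound 2 `COc1cc(-c2ccnc3cc(-c4cn(C(=O)OC(C)(C)C)c5ccccc45)nn23)cc(OC)c1OC` gives 3770 nM in this assay, a gap beyond the usual scatter. Compound 3 `COc1cc(-c2ccnc3cc(-c4ccc5cnn(C)c5c4)nn23)cc(OC)c1OC` has not yet been measured; it differs from compound 1 by 1-methyl-1H-indazol-6-yl in place of 1H-indol-6-yl on an aromatic carbon, so the hydrogen-bond donor of compound 1 is gone. Within the data shown here, no single step of this kind has been measured, and a modest weakening is expected, a 3.2-fold higher number from compound 1 to compound 3 (0.51 log units; beyond the scatter) in this assay. Compound 3 is therefore estimated at 400 nM in this assay, between 120 nM and 1500 nM.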

Compound 3, half-maximal inhibitory concentration: 97 nM
The estimate for compound 3 lay 4.1-fold (0.62 log units) above the measured number; the whole stated range lies above it.
By their numbers in this assay, from the lowest: compounds 3 and 1 (each within the scatter of the next); then compound 2.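

In this assay, 1-methyl-1H-indazol-6-yl in place of 1H-indol-6-yl gives a 1.3-fold lower number from compound 1 to compound 3 (0.11 log units; within the scatter). At this position, then, the hydrogen-bond donor of compound 1 can go without a shift beyond the scatter, and the bicyclic group can take a methyl and a second ring nitrogen. No outside evidence explains why this change is tolerated.

Within the data shown here, the single step cannot separate the methyl from the added ring nitrogen. From the compounds shown here alone, whether a longer chain in place of that methyl, or an amine or carboxylic acid on this group, would be tolerated stays open.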